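This account rests on a few compounds, and the source may have more. Where it says the series, first, only, none or still open, it means among the compounds named here.

Compound 1 `CC(C)N(Cc1cccc(OCCCCCC(=O)O)c1)C(=O)c1ccc(-c2ccncc2)cc1` gives > 26000 nM in an ADME assay on HEK293 cells (Homo sapiens) for cytotoxicity, read by CellTiter-Glo and resazurin assay, with a stated time of 72 h (a higher number here means that more compound is needed for the effect, a lower number that less compound is needed), which is a limit of the assay and not a number.
Compound 2 `CC(C)N(Cc1cccc(OCCCCCC(=O)O)c1)C(=O)c1ccc(-c2ccc3cc[nH]c3c2)cc1` gives > 26000 nM in this assay, again a limit.
Compound 3 `CCOC(=O)CCCCCOc1cccc(CN(C(=O)c2ccc(-c3ccncc3)cc2)C(C)C)c1` gives > 26000 nM in this assay, again a limit.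

All three measured compounds therefore sit at the same place, (the limit of > 26000 nM in this assay, at which 3 of the 3 values shown sit), and compound 3 stands nowhere above or below its neighbours: it is at the limit like the other two. The two steps that connect the measured compounds, a step that the two limits leave unreadable from compound 1 to compound 2 and a step that the two limits leave unreadable from compound 1 to compound 3, are both unreadable, since each joins two limits.

The unmeasured compound 4 `CCOC(=O)CCCCCOc1cccc(CN(C(=O)c2ccc(-c3cccc(-c4nnc(C)o4)c3)cc2)C(C)C)c1` differs from compound 3 in one place: 3-(5-methyl-1,3,4-oxadiazol-2-yl)phenyl in place of pyridin-4-yl on an aromatic carbon. For the measured compounds named here, the only measured step that touches the same aromatic carbon is the one from compound 1 to compound 2, and it gives no readable size; the step from compound 1 to compound 3 concerns the ester end of the chain and is equally silent. Going by the values given here, no measured step therefore bears readably on this change, and no step beyond the scatter can be predicted in this assay in either direction.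

Compound 4 is thus expected to remain at the limit, with an estimate of about 30000 nM and a range from 15000 nM to 60000 nM. The expected step that the limit leaves unreadable from compound 3 to compound 4 is one that would not be told apart from the scatter.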

Compound 4, half-maximal effective concentration: > 26000 nM
Compound 4 was reported as a limit; the forecaster's own chance of this, stated with the estimate: 80%; the middle value lies beyond the limit too.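

No step can be read between compound 3 and compound 4, as both are reported only as limits of the assay, not as numbers: the limit of > 26000 nM in this assay, at which 4 of the 4 values shown sit. The compounds shown leave open at what concentration any of them has an effect in this assay, and whether a change on the aromatic carbon or at the ester end alters that concentration.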